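A few compounds are considered here, and "the series" means these few. Any claim that something is new, unique, unknown or untested is made for them only; others in the source may bear on it.

Measured in a functional assay on SK-OV-3 cells (Homo sapiens) for antiproliferative activity, read by MTT assay, with a stated time of 72 h; on this read-out higher numbers stand for weaker inhibition and lower numbers for stronger inhibition:
- compound 1 `CC(=O)c1ccc(-c2cccc(NC(=O)CCc3ccc4c(c3)B(O)OC4)c2)cc1`: > 100000 nM, a limit of the assay and not a number
- compound 2 `COc1cc(OC)cc(-c2cccc(NC(=O)CCc3ccc4c(c3)COB4O)c2)c1`: 93000 nM

In this assay, going by the values given here, compound 2 at 93000 nM holds the only actual number so far. The other result is a limit, as the limit of > 100000 nM in this assay, at which 1 of the 2 values shown sits, records.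

The next compound is compound 3 `CC(=O)c1ccc(-c2cccc(NC(=O)CCc3ccc4c(c3)COB4O)c2)cc1`. It changes the aryl group of compound 2: 4-acetylphenyl in place of 3,5-dimethoxyphenyl on an aromatic carbon, with 4-acetylphenyl in place of 3,5-dimethoxyphenyl on an aromatic carbon, meta to a large group.

Among the compounds with values here, no measured step sizes this change. Compound 1 also carries the 4-acetylphenyl group, and its result is the limit > 100000 nM. With compound 2 already showing only weak inhibition at 93000 nM, no change beyond the scatter is expected in this assay. A result for compound 3 reported only as a limit would not be surprising. The estimated size of the change, a 1.0-fold lower number from compound 2 to compound 3 (0.01 log units; within the scatter), is expected to stay within the scatter. For compound 3 the estimated value is 90000 nM, with an expected range of 40000 nM to 160000 nM.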

Compound 3, half-maximal inhibitory concentration: 79000 nM
Beside the measured number, compound 3's estimate is 1.1-fold (0.06 log units) above it, within the range that was stated.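

In this assay, the step of a 1.2-fold lower number from compound 2 to compound 3 (0.07 log units; within the scatter) shows that on this aromatic carbon, meta to a large group, the exchange of 3,5-dimethoxyphenyl for 4-acetylphenyl gives no change that can be told from the scatter, so these two aryl groups cannot be separated on this read-out. The second comparison, an at least 1.2-fold lower number from compound 1 to compound 3 (0.10 log units; that floor lies within the scatter), concerns only the group on the saturated chain carbon, two bonds along the chain from a carbonyl carbon, and with both compounds carrying 4-acetylphenyl it sets a floor that does not separate them beyond the scatter. Compound 1 still stands as a limit of the assay and not a number: the limit of > 100000 nM in this assay, at which 1 of the 3 values shown sits.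

From the compounds shown here alone, whether any group at this aromatic carbon can move the number beyond the scatter remains open, for instance an amine or a carboxylic acid in place of the acetyl group of compound 3. Also open, going by these compounds, is how far the true value of compound 1 lies from that of compound 3, and whether a longer chain between the carbonyl carbon and the core would change the result.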